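Compound 2 to compound 3: bromo in place of chloro

A few compounds are considered here, and "the series" means these few. Any claim that something is new, unique, unknown or untested is made for them only; others in the source may bear on it.

Measured in an ADME assay on HeLa cells (Homo sapiens) for cytotoxicity, read by MTT assay, with a stated time of 72 h; a lower number here means a stronger inhibitor of growth, a higher number a weaker inhibitor of growth:
compound 1 `O=C(/C=C\c1ccccc1[N+](=O)[O-])N1N=C(c2ccncc2)OC1c1c[nH]c2ccccc12`: > 30 ug/mL (a limit)
compound 2 `O=C(/C=C\c1ccc(Cl)cc1)N1N=C(c2ccncc2)OC1c1c[nH]c2ccccc12`: > 30 ug/mL (a limit)

Compound 2 stands at a limit, > 30 ug/mL, and has no number of its own. Compound 1 stands at a limit too, at > 30 ug/mL. For the measured compounds named here, the only measured step, a step that the two limits leave unreadable from compound 1 to compound 2, therefore gives no size to carry forward, and the evidence amounts to the limit of > 30 ug/mL in this assay, at which 2 of the 2 values shown sit.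

Compound 3 `O=C(/C=C\c1ccc(Br)cc1)N1N=C(c2ccncc2)OC1c1c[nH]c2ccccc12` is the next case, with bromo in place of chloro on an aromatic carbon, para to a large group. No step beyond the scatter is expected in this assay, and no direction can be expected either. The estimated change is a step that the limit leaves unreadable from compound 2 to compound 3. For compound 3 the expected value is 40 ug/mL, with an estimated range of 18 ug/mL to 90 ug/mL.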

Compound 3, concentration for 50% growth inhibition: > 30 ug/mL
Compound 3: a limit, no number (the forecaster's own chance of this, stated with the estimate: 85%); the middle value is on the limit's open side.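

In this assay compound 3 gives > 30 ug/mL, which is a limit and not a number. The steps to compound 3 from compound 1 and from compound 2 therefore cannot be read. The compounds shown leave open whether 4-bromophenyl and 4-chlorophenyl differ in this assay.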